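The source may report more compounds than this note shows. Statements on the series, on what has been measured and on what is new or still open speak of the compounds shown alone.

Going by the values given here, compound 1 `CC1(C)C(=O)Nc2ccc(OCc3cccc(Cl)c3)cc21` is one of two compounds measured in an assay on cells for inhibition of Amine oxidase [flavin-containing] A (Homo sapiens), read by fluorescence, with stated times of 30 min and 15 min; a higher number here means a weaker inhibitor, a lower number a stronger inhibitor. In this assay compound 1 gives only a limit, > 500000 nM. Compound 2 `O=C1Cc2cc(OCCc3ccc(F)cc3)ccc2N1` likewise gives only a limit in this assay, > 500000 nM. Both values shown sit at the limit of > 500000 nM in this assay, at which 2 of the 2 values shown sit, so no number is known for either. Compound 3 `CC1(C)C(=O)Nc2ccc(OCc3ccc(Cl)c(Cl)c3)cc21` differs from compound 1 by chloro in place of hydrogen on an aromatic carbon. Among the compounds with values here, no measured step exists for this change, and both values shown are limits, so no shift beyond the scatter is expected. The step from compound 1 to compound 3 is estimated at a step that the limit leaves unreadable from compound 1 to compound 3. Compound 3 is therefore expected at 800000 nM, between 300000 nM and 3000000 nM, and most probably again reported as a limit.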

Compound 3, half-maximal inhibitory concentration: > 500000 nM
Compound 3 was reported as a limit; the forecaster's own chance of this, stated with the estimate: 85%; the middle value does not contradict the limit.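

No step can be read from compound 1 to compound 3, since both give only limits in this assay: the limit of > 500000 nM in this assay, at which 3 of the 3 values shown sit.

The compounds shown leave open which change to the shared core, if any, would give a number in this assay.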